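This account rests on a few compounds, and the source may have more. Where it says the series, first, only, none or still open, it means among the compounds named here.

Of the compounds shown here, three from this series have been tested for how much of them cultured mouse macrophages tolerate in an ADME assay on cells (Peritoneal macrophage, Mus musculus, strain Balb/c) for cytotoxicity, read by resazurin assay, with a stated time of 72 h; a higher number here means that more compound is tolerated, a lower number that less compound is tolerated. Compound 2 `CC1(Cc2ccc([N+](=O)[O-])cc2)CC(S(=O)(=O)c2ccc(F)cc2)=C(c2ccc(/C(N)=N/O)cc2)O1` gives 97400 nM, the highest of the three numbers. Compound 1 `CCC1(CC)CC(S(=O)(=O)c2ccc(F)cc2)=C(c2ccc(/C(N)=N/O)cc2)O1` gives 91400 nM, which lies within the scatter of compound 2, so the two cannot be ordered. Among the measured compounds shown here, compound 3 `CC1(Cc2ccc(-c3ccccc3)cc2)CC(S(=O)(=O)c2ccc(F)cc2)=C(c2ccc(/C(N)=N/O)cc2)O1` gives 33900 nM, and the single step in this set, a 2.9-fold lower number from compound 2 to compound 3 (0.46 log units; beyond the scatter), shows that exchanging the small nitro group for a second aromatic ring on the benzyl arm lowered the tolerated concentration beyond the scatter.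

Compound 4 `CC1(/C=C/c2ccc(C(F)(F)F)cc2)CC(S(=O)(=O)c2ccc(F)cc2)=C(c2ccc(/C(N)=N/O)cc2)O1` has not yet been measured. Its change from compound 2 is 2-(4-(trifluoromethyl)phenyl)ethenyl in place of 4-nitrobenzyl on a saturated ring carbon. Like the step from compound 2 to compound 3, this change removes the nitro group and enlarges the arm that sits on the saturated ring carbon, now by an ethenyl link to a ring carrying trifluoromethyl. For the measured compounds named here, only that one step bears on the question, and it was modest. A modest lowering of the number is therefore expected, about a 2.2-fold lower number from compound 2 to compound 4 (0.34 log units; beyond the scatter), though with one step as guide the uncertainty is wide. For compound 4 the expected value in this assay is 45000 nM, within a range from 20000 nM to 100000 nM.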

Compound 4, half-maximal cytotoxic concentration: 43900 nM
The estimate for compound 4 lay 1.0-fold (0.01 log units) above the measured number; the range from low to high includes it.
By their numbers in this assay, from the lowest: compounds 3 and 4 (each within the scatter of the next); then compounds 1 and 2 (each within the scatter of the next).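

Replacing 4-nitrobenzyl on the saturated ring carbon with 2-(4-(trifluoromethyl)phenyl)ethenyl gives a 2.2-fold lower number from compound 2 to compound 4 (0.35 log units; beyond the scatter) in this assay, so the lower number seen with compound 3 is no longer tied to a single arm. Compound 3 at 33900 nM and compound 4 at 43900 nM lie within the scatter of each other, even though the two arms differ in their link to the outer ring and in what that ring carries. No measurement here explains why either arm lowers the tolerated concentration, so the result stays an observation without a shown cause.

Compound 4 brings in the ethenyl link and the trifluoromethyl group together, so the compounds shown cannot separate their contributions; a 4-(trifluoromethyl)benzyl arm would test the group without the ethenyl link. It also remains open how macrophages would tolerate an arm ending in an amine or a carboxylic acid, since every arm shown on this carbon is either a pair of ethyl groups or ends in an aromatic ring.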